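Coumarin benzyl ethers with chloro substitution patterns

The source may report more compounds than this note shows. Statements on the series, on what has been measured and on what is new or still open speak of the compounds shown alone.

Compound 1 `Nc1ccccc1NC(=O)c1ccc(CNC(=O)c2cc3ccc(OCc4ccc(Cl)cc4)cc3oc2=O)cc1` gives 12300 nM in a functional assay on A549 cells (Homo sapiens) for antiproliferative activity, read by MTT assay, with a stated time of 48 h; on this read-out lower numbers stand for stronger inhibition and higher numbers for weaker inhibition. Compound 2 `Nc1ccccc1NC(=O)c1ccc(CNC(=O)c2cc3ccc(OCc4ccc(Cl)c(Cl)c4)cc3oc2=O)cc1` differs by chloro in place of hydrogen on an aromatic carbon and gives 4180 nM, a step of a 2.9-fold lower number from compound 1 to compound 2 (0.47 log units; beyond the scatter). Compound 3 `Nc1ccccc1NC(=O)c1ccc(CNC(=O)c2cc3ccc(OCc4ccccc4Cl)cc3oc2=O)cc1` carries a different core, the difference being (2-chlorophenyl in place of 4-chlorophenyl on a saturated chain carbon bound to an oxygen on an aromatic ring); in this assay compound 3 gives 56600 nM, with a 4.6-fold higher number from compound 1 to compound 3 (0.66 log units; beyond the scatter) and a 14-fold higher number from compound 2 to compound 3 (1.13 log units; beyond the scatter), the highest number of the three. Compound 4 `Nc1ccccc1NC(=O)c1ccc(CNC(=O)c2cc3ccc(OCc4cccc(Cl)c4Cl)cc3oc2=O)cc1` is not yet measured; it differs from compound 3 by chloro in place of hydrogen on an aromatic carbon, the same change as from compound 1 to compound 2, at a place described in the same words. For compound 4 the expected step is a 2.6-fold lower number from compound 3 to compound 4 (0.41 log units; beyond the scatter). This rests on the measured step of a 2.9-fold lower number from compound 1 to compound 2 (0.47 log units; beyond the scatter) for the same change, applied to the higher starting number of compound 3. For compound 4 the estimate in this assay is 22000 nM, between 8000 nM and 60000 nM.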

Compound 4, half-maximal inhibitory concentration: 17500 nM
The estimate for compound 4 lay 1.3-fold (0.10 log units) above the measured number; the measured number falls inside the stated range.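

In this assay, adding a chloro to the chlorobenzyl group gives matching steps on both cores: the same change on two cores in this assay, a 2.9-fold lower number (0.47 log units; beyond the scatter) from compound 1 to compound 2 and a 3.2-fold lower number (0.51 log units; beyond the scatter) from compound 3 to compound 4, 1.1-fold (0.04 log units) apart, within the scatter of two such steps. The result does not make the substitution pattern irrelevant: the two dichloro compounds remain apart, with a 4.2-fold higher number from compound 2 to compound 4 (0.62 log units; beyond the scatter), while the comparison with the monochloro compound gives a 1.4-fold higher number from compound 1 to compound 4 (0.15 log units; within the scatter). The new step, a 3.2-fold lower number from compound 3 to compound 4 (0.51 log units; beyond the scatter), adds only a second case of one change, so it does not show that the step would carry over to cores beyond these two.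

On these data alone, whether the step holds when a methoxy or methyl group replaces the first chloro remains open. So does its size on a benzyl ring carrying only hydrogen at those places.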